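The compounds below may be only part of what the source reports. "The series", "measured", "known", "first", "only" and "open" are said of these compounds alone.

Three compounds share one core, and their numbers in an assay on isolated protein for inhibition of melanin-concentrating hormone receptor 1 (Homo sapiens) (on this read-out lower numbers stand for stronger inhibition and higher numbers for weaker inhibition), are all close together. Compound 1 `CN(C)CCN(C(=O)Nc1cc(Cl)cc(Cl)c1)c1ccc(-c2cccc(C#N)c2)cc1` gives 19 nM in this assay. Compound 2 `CNCCN(C(=O)Nc1ccc(F)c(Cl)c1)c1ccc(-c2cccc(C#N)c2)cc1` gives 6 nM in this assay. Compound 3 `N#Cc1cccc(-c2ccc(N(CCN3CC[C@@H](O)C3)C(=O)Nc3cc(Cl)cc(Cl)c3)cc2)c1` gives 11 nM in this assay. Compound 3 thus sits between the other two, with compound 1 on one side and compound 2 on the other, and both gaps are within the scatter of this assay, so no order among the three can be claimed.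

For the measured compounds named here, the one step that can be followed directly runs a 1.7-fold lower number from compound 1 to compound 3 (0.24 log units; within the scatter), a change on the chain that left the number essentially where it was.

Compound 4 `N#Cc1cccc(-c2ccc(N(CCN3CC[C@@H](O)C3)C(=O)Nc3ccc(F)c(Cl)c3)cc2)c1` is the next compound, not yet measured. It differs from compound 3 as follows: 3-chloro-4-fluorophenyl in place of 3,5-dichlorophenyl on an amide-type nitrogen. Going by the values given here, no measured pair differs in this place alone. Compound 2 carries the entering group together with a different chain, and compound 2 gives 6 nM in this assay, while the dichlorophenyl compounds 1 and 3 give their values above, all within the scatter of one another. For compound 4 a step of a 1.6-fold lower number from compound 3 to compound 4 (0.20 log units; within the scatter) is therefore expected, no larger than the scatter. Compound 4 is estimated at 7 nM, with a range from 3 nM to 18 nM.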

Compound 4, inhibition constant: 7.1 nM
For compound 4 the middle estimate is 1.0-fold (0.01 log units) below the measured one; low and high end bracket the measured number.
By their numbers in this assay, from the lowest: compounds 2, 4, 3 and 1 (each within the scatter of the next, the first and the last beyond it).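

For the compounds shown here, compound 4 gives the first direct reading at this position: with the rest of the molecule held fixed in this assay, putting 3-chloro-4-fluorophenyl in place of 3,5-dichlorophenyl on the amide-type nitrogen gives a 1.5-fold lower number from compound 3 to compound 4 (0.19 log units; within the scatter) and so leaves no change that can be told from the scatter. It also gives a second reading of the chain, now with 3-chloro-4-fluorophenyl in place: 3-hydroxypyrrolidin-1-yl in place of methylamino gives a 1.2-fold higher number from compound 2 to compound 4 (0.07 log units; within the scatter), again within the scatter, so both changes of the chain amine seen so far, this one and the earlier step with 3,5-dichlorophenyl, leave the number where it was. Nothing measured on these compounds says why either part can be exchanged with so little trace in this read-out.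

From the compounds shown here alone, all the rings on this nitrogen so far carry chlorine, so it remains open whether an unsubstituted phenyl ring, or one carrying a methoxy group, would stay in the same range. The compounds shown also leave open what a longer chain before the amine, or a carboxylic acid in place of the nitrile, would do to the number.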